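This account rests on a few compounds, and the source may have more. Where it says the series, first, only, none or still open, it means among the compounds named here.

Measured so far:
compound 1, `COc1ccccc1/C=c1\c(=O)[nH]/c(=C/c2cccc(Cl)c2Cl)c(=O)n1C`, 300 nM
compound 2, `C=CCn1c(=O)/c(=C\c2cc(F)ccc2C)[nH]c(=O)/c1=C\c1ccccc1OC`, 7300 nM
compound 3, `C=CCn1c(=O)/c(=C\c2cccc(Br)c2)[nH]c(=O)/c1=C\c1cccc(Br)c1`, "not active" (no number reported)

In a functional assay on NCI-H1975 cells (Homo sapiens) for cytotoxicity, read by CCK-8 assay, with a stated time of 72 h (a higher number here means a weaker inhibitor, a lower number a stronger inhibitor), compound 1 gives 300 nM, and compound 2 gives 7300 nM. Of the two numbers that exist, compound 2 holds the higher one and compound 1 the lower, and the gap between them lies beyond the usual scatter of this assay . Compound 3 gives no number at all, only the statement that it is not active. Among the measured compounds shown here, no pair of measured compounds differs in only one place, so no measured step is available to size the change now considered.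

The next compound is compound 4, `C=CCn1c(=O)/c(=C\c2ccccc2F)[nH]c(=O)/c1=C\c1ccccc1OC`. Against compound 2 the change is 2-fluorophenyl in place of 5-fluoro-2-methylphenyl on a double-bonded chain carbon bound to an aromatic carbon. The shared core and the allyl chain stay as in compound 2, and the 2-methoxyphenyl on the other side is unchanged.

For the measured compounds named here, with no measured step of this kind to lean on, the expectation for compound 4 rests on compound 2 alone, whose value of 7300 nM sets the starting point. Any shift in this assay is expected to be small, and not clearly beyond the scatter in either direction. Compound 4 is therefore estimated to give 5000 nM, with a range from 1000 nM to 25000 nM. This estimate means an expected step of a 1.5-fold lower number from compound 2 to compound 4 (0.16 log units; within the scatter), which stays inside the scatter.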

Compound 4, half-maximal inhibitory concentration: 25100 nM
The estimate for compound 4 lay 5.0-fold (0.70 log units) below the measured number; measured number above the stated range.
By their numbers in this assay, from the lowest: compound 1; then compound 2; then compound 4.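

In this assay, among the compounds shown here, the change from 5-fluoro-2-methylphenyl to 2-fluorophenyl on a double-bonded chain carbon bound to an aromatic carbon gives the first measured step at this place: a 3.4-fold higher number from compound 2 to compound 4 (0.54 log units; beyond the scatter). The shared core, the allyl chain and the 2-methoxyphenyl stay the same, so this place alone separates the two numbers, and the simpler 2-fluorophenyl, with 7 heavy atoms against 8, goes with the weaker result. No available evidence bears on why the number moves in this direction.

The two groups differ both in the methyl and in the number attached to the fluoro in their names, so the step cannot be divided between these two differences, and a 2-methylphenyl or an unsubstituted phenyl at this place would be needed to separate them. From the compounds shown here alone, it also remains open whether a step of this size would hold with a longer chain in place of the allyl, or whether an amine on this aromatic ring would bring the number back down.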